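This account rests on a few compounds, and the source may have more. Where it says the series, first, only, none or still open, it means among the compounds named here.

Measured so far in a functional assay for antagonist activity at integrin alpha-5/beta-1 (Homo sapiens), read by ELISA; on this read-out lower numbers stand for stronger inhibition and higher numbers for weaker inhibition:
- compound 1, `Cc1cc(C)c(S(=O)(=O)N[C@@H](CNC(=O)C2=NO[C@@]3(C2)C[C@@H](CNC2N=CC=N2)N(C(=O)OCc2ccccc2)C3)C(=O)O)c(C)c1`, gives 1200 nM
- compound 2, `Cc1cc(-c2ccccc2)cc(C)c1S(=O)(=O)[C@@H](CNC(=O)C1=NOC2(CCC(CNc3ncc[nH]3)CC2)C1)C(=O)O`, gives 670 nM

Compound 2 holds the lower of these two numbers, and compound 1 the higher, but the gap between them lies within the usual scatter of this assay, so the two values cannot be told apart with confidence. The two compounds also differ in more than one place, so no single structural cause can be read from them.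

Compound 3, `Cc1cc(C)c(S(=O)(=O)[C@@H](CNC(=O)C2=NOC3(CCC(CNc4ncc[nH]4)CC3)C2)C(=O)O)c(C)c1`, shares its core with compound 2 and differs from it in one place: methyl in place of phenyl on an aromatic carbon. For the measured compounds named here, no measured pair shows what this exchange does on this core. Compound 1 carries the same trimethyl-substituted ring on a different core and gives 1200 nM, which sits close to compound 2. The expectation is therefore a small step, if any, most likely toward a somewhat higher number, and not clearly beyond the scatter. Compound 3 is expected to give about 1000 nM, within a range from 400 nM to 3000 nM. This estimate means a step of a 1.5-fold higher number from compound 2 to compound 3 (0.17 log units; within the scatter), expected to be modest.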

Compound 3, half-maximal inhibitory concentration: 1500 nM
Compound 3: middle estimate off by 1.5-fold (0.18 log units), on the low side; the measured number falls inside the stated range.
By their numbers in this assay, from the lowest: compounds 2, 1 and 3 (each within the scatter of the next, the first and the last beyond it).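

In this assay the exchange of phenyl for methyl on the shared core gives a 2.2-fold higher number from compound 2 to compound 3 (0.35 log units; beyond the scatter) and so shows, for the first time among these compounds, that the aromatic carbon para to a large group is not indifferent to what it carries. The step is modest, but it lies beyond the scatter, and it favours phenyl: the larger group is accepted at this carbon, and the compound carrying it has the lower number. Neither group has hydrogen-bond donors, hydrogen-bond acceptors or a net charge, and nothing measured here says what lies behind the step.

For the compounds shown here, a single pair gives only two points on this core, so it cannot show whether the number follows the size of the group or something particular to phenyl. A hydrogen atom, a methoxy group, a pyridyl ring or a phenyl bearing a fluorine atom on this same carbon would be needed to tell whether this step is part of a wider trend.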